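The compounds below may be only part of what the source reports. "The series", "measured", "known", "first", "only" and "open" are said of these compounds alone.

Measured compounds:
compound 1 `Cc1ccccc1-n1cc(-c2ccccc2NS(=O)(=O)c2c[nH]c(=O)[nH]c2=O)nn1` — 19900 nM
compound 2 `Cc1cccc(-n2cc(-c3ccccc3NS(=O)(=O)c3c[nH]c(=O)[nH]c3=O)nn2)c1` — 23700 nM

In an ADME assay on GES1 cells (Homo sapiens) for cytotoxicity, read by MTT assay, with a stated time of 24 h (a lower number here means that less compound is tolerated, a higher number that more compound is tolerated), compound 1 holds the lower of the two numbers, though a 1.2-fold higher number from compound 1 to compound 2 (0.08 log units; within the scatter) lies within the scatter, so the two are not separated. Compound 3 `O=c1[nH]cc(S(=O)(=O)Nc2ccccc2-c2cn(-c3ccccc3Cl)nn2)c(=O)[nH]1` is not yet measured; it differs from compound 1 by chloro in place of methyl on an aromatic carbon. Among the compounds with values here, the only measured step, a 1.2-fold higher number from compound 1 to compound 2 (0.08 log units; within the scatter), concerns another change and is itself within the scatter, so nothing measured bears directly on chloro in place of methyl. The expected step is a 1.0-fold higher number from compound 1 to compound 3 (0.00 log units; within the scatter), that is none beyond the scatter. Compound 3 is estimated at 20000 nM, range 8000 nM to 50000 nM.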

Compound 3, half-maximal cytotoxic concentration: 20800 nM
Beside the measured number, compound 3's estimate is 1.0-fold (0.02 log units) below it; the range from low to high includes it.
By their numbers in this assay, from the lowest: compounds 1, 3 and 2 (each within the scatter of the next).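

Chloro in place of methyl, on an aromatic carbon ortho to a large group, gives in this assay a 1.0-fold higher number from compound 1 to compound 3 (0.02 log units; within the scatter) and so is not separated from methyl at this position. The 2-chlorophenyl and 3-methylphenyl compounds also stay together, with a 1.1-fold lower number from compound 2 to compound 3 (0.06 log units; within the scatter) inside the scatter, so all three aryl variants remain unresolved in this cell read-out. No measurement shown accounts for this flat result.

Open, going by these compounds, is whether a more different substituent here, such as an amine, a carboxylic acid or a longer chain, would move the number beyond the scatter. Also open, on these data alone, is whether 3-chlorophenyl would stay with these three compounds.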